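Swapping an ortho fluoro for methyl on a kinase-type scaffold

The source may report more compounds than this note shows. Statements on the series, on what has been measured and on what is new or still open speak of the compounds shown alone.

Of the compounds shown here, two have been measured. Compound 1, `COc1cc2c(Oc3ccc(NC(=O)c4cn(-c5ccccc5C)nn4)cc3F)ccnc2cc1OCCCN1CCCC1`, gives 1200 nM in a functional assay on HT-29 cells (Homo sapiens) for cytotoxicity, read by MTT assay, with a stated time of 72 h; a lower number here means a stronger inhibitor, a higher number a weaker inhibitor. Compound 2, `COc1cc2c(Oc3ccc(NC(=O)c4cn(-c5ccccc5F)nn4)cc3F)ccnc2cc1OCCCN1CCN(C)CC1`, gives 300 nM in this assay, the lowest of the two numbers, with compound 1 standing higher by a gap beyond the usual scatter. Compound 1 and compound 2 differ in two places at once, in the amine at the end of the side chain and on the phenyl ring attached to the triazole, so their two values by themselves do not tell which change matters.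

Compound 3, `COc1cc2c(Oc3ccc(NC(=O)c4cn(-c5ccccc5C)nn4)cc3F)ccnc2cc1OCCCN1CCN(C)CC1`, keeps the side chain of compound 2 and changes only the phenyl ring: methyl in place of fluoro on an aromatic carbon. Within the data shown here, since no pair of measured compounds isolates this one change, the expected step is taken as small and toward a higher number, with the methyl ring of compound 1 as the only hint. Compound 3 is therefore expected to sit at 600 nM in this assay, between 200 nM and 2000 nM, an estimated step of a 2.0-fold higher number from compound 2 to compound 3 (0.30 log units; within the scatter).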

Compound 3, half-maximal inhibitory concentration: 1430 nM
Compound 3: the middle estimate sits 2.4-fold (0.38 log units) below what was measured; low and high end bracket the measured number.
By their numbers in this assay, from the lowest: compound 2; then compounds 1 and 3 (each within the scatter of the next).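

In this assay, methyl in place of fluoro on the phenyl ring attached to the triazole gives a 4.8-fold higher number from compound 2 to compound 3 (0.68 log units; beyond the scatter) with the side chain held fixed, so this exchange of one heavy atom for another, ortho to a large group, is enough on its own to produce a step beyond the scatter. Keeping the 2-methylphenyl ring and putting 4-methylpiperazin-1-yl in place of pyrrolidin-1-yl gives a 1.2-fold higher number from compound 1 to compound 3 (0.08 log units; within the scatter) and stays within the scatter, so on this ring the two amines cannot be told apart. Of the two places that were tangled together before, the phenyl position now has a step beyond the scatter and the amine does not, though the amine has been read only with the methyl ring in place.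

No measurement shown here accounts for the size of the step from fluoro to methyl. From the compounds shown here alone, it also remains open whether that step would hold with the pyrrolidin-1-yl side chain, and where a chloro, a methoxy or a plain hydrogen at this same position would fall.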